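Swapping an Amine Side Chain for Chloro

A few compounds are considered here, and "the series" means these few. Any claim that something is new, unique, unknown or untested is made for them only; others in the source may bear on it.

For the measured compounds named here, in a functional assay on DLD-1 cells (Homo sapiens) for cytotoxicity, read by MTT assay, with a stated time of 48 h (a higher number here means a weaker inhibitor, a lower number a stronger inhibitor), compound 3 `C=CCOc1ccc2c(NCCCN(C)C)ccnc2c1` gives 5180 nM, the highest of the three numbers measured so far, though all three sit within the usual scatter of one another. Compound 1 `CC(C)COc1ccc2c(Cl)ccnc2c1` gives 3100 nM, and compound 2 `CCCCCCOc1ccc2c(Cl)ccnc2c1` gives 2660 nM. Going by the values given here, the only measured step, a 1.2-fold lower number from compound 1 to compound 2 (0.07 log units; within the scatter), alters just the saturated chain bound to the aromatic oxygen and shows nothing beyond the scatter; it does not touch the change now in question. Compound 4 `C=CCOc1ccc2c(Cl)ccnc2c1` arises from compound 3 by chloro in place of (3-(dimethylamino)propyl)amino on an aromatic carbon. Among the compounds with values here, no measured pair contrasts the amine side chain with chloro directly, but compounds 1 and 2 already carry chloro and lie close to compound 3, which points toward compound 4 landing near them. The step of a 1.7-fold lower number from compound 3 to compound 4 (0.24 log units; within the scatter) is therefore expected to remain within the scatter, and compound 4 is estimated at 3000 nM, with a likely range from 1400 nM to 6500 nM in this assay.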

Compound 4, half-maximal inhibitory concentration: 2890 nM
Beside the measured number, compound 4's estimate is 1.0-fold (0.02 log units) above it; the measured number falls inside the stated range.
By their numbers in this assay, from the lowest: compounds 2, 4, 1 and 3 (each within the scatter of the next).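

For the compounds shown here, at this aromatic carbon, opposite the ring nitrogen, this assay gives the first direct reading of the exchange: a 1.8-fold lower number from compound 3 to compound 4 (0.25 log units; within the scatter) shows that a single chloro can stand in place of the whole (3-(dimethylamino)propyl)amino side chain without moving the number outside the scatter. Compound 4 also links the chloro compounds, and the changes on the chain bound to the oxygen, a 1.1-fold higher number from compound 2 to compound 4 (0.04 log units; within the scatter) and a 1.1-fold lower number from compound 1 to compound 4 (0.03 log units; within the scatter), likewise stay within the scatter. No supporting measurement here accounts for these results.

Still open, from the compounds shown here alone, is whether another group at this carbon, such as a morpholine or a shorter amine chain, would separate from these compounds beyond the scatter. Also open, going by these compounds, is whether a carboxylic acid on the chain bound to the oxygen would do so.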